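A few compounds are considered here, and "the series" means these few. Any claim that something is new, unique, unknown or untested is made for them only; others in the source may bear on it.

Measured so far:
compound 1 `C/C(=C\c1ccc(NC(=O)Nc2ccc(Cl)c(C(F)(F)F)c2)cc1)C(=O)NC(C)c1ccccc1`: > 50000 nM in a functional assay on MX1 cells (Homo sapiens) for inhibition, read by MTT assay, with a stated time of 120 h; a higher number here means a weaker inhibitor, a lower number a stronger inhibitor
compound 2 `CC(NC(=O)/C=C/Oc1ccc(NC(=O)Nc2cc(C(F)(F)F)ccc2Cl)cc1)c1ccccc1`: 16100 nM in this assay

For compound 1 the entry > 50000 nM is a limit of the assay, not a number (the limit of > 50000 nM in this assay, at which 1 of the 2 values shown sits). Compound 2 therefore holds the only numeric result in this assay, at 16100 nM. Compound 3 `CC(NC(=O)/C=C/Oc1ccc(NC(=O)Nc2ccc(Cl)c(C(F)(F)F)c2)cc1)c1ccccc1` remains to be measured. It differs from compound 2 by 4-chloro-3-(trifluoromethyl)phenyl in place of 2-chloro-5-(trifluoromethyl)phenyl on an amide-type nitrogen, the same group compound 1 carries. For the measured compounds named here, no measured step covers this change. A weakening step a 1.9-fold higher number from compound 2 to compound 3 (0.27 log units; within the scatter) is expected, with a real chance of a limit only. Compound 3 is estimated at 30000 nM, range 8000 nM to 100000 nM.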

Compound 3, half-maximal inhibitory concentration: 13700 nM
Beside the measured number, compound 3's estimate is 2.2-fold (0.34 log units) above it; measured number inside the range.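

The exchange of 2-chloro-5-(trifluoromethyl)phenyl for 4-chloro-3-(trifluoromethyl)phenyl on an amide-type nitrogen is a 1.2-fold lower number from compound 2 to compound 3 (0.07 log units; within the scatter) in this assay, so these two arrangements of the same atoms cannot be told apart here. Compound 1 carries the same 4-chloro-3-(trifluoromethyl)phenyl group, and its entry of > 50000 nM is a limit of the assay, not a number. Nothing measured here accounts for this result.

Open, going by these compounds, is whether a different group on this nitrogen, such as an unsubstituted phenyl or a pyridine ring, would give a step beyond the scatter. Also open, on these data alone, is the effect of an amine or a carboxylic acid on this ring in place of chlorine or trifluoromethyl.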